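This account rests on a few compounds, and the source may have more. Where it says the series, first, only, none or still open, it means among the compounds named here.

The study covers two measured compounds and one still to be measured. Compound 1 `O=c1nc(-c2ccccc2)c2cc(-c3ccccc3)ccc2[nH]1` is the simplest member of the set. In an ADME assay on THP-1 cells (Homo sapiens) for cytotoxicity, read by MTT assay, with a stated time of 72 h (a higher number here means that more compound is needed for the effect, a lower number that less compound is needed), compound 1 gives > 50000 nM, which is a limit of the assay rather than a number. Compound 2 `O=c1nc(-c2ccccc2)c2cc(-c3cccc(F)c3)ccc2[nH]1` carries fluoro in place of hydrogen on an aromatic carbon. In this assay compound 2 gives > 50000 nM, again a limit and not a number. The step that the two limits leave unreadable from compound 1 to compound 2 therefore cannot be read, because both values sit at the limit of > 50000 nM in this assay, at which 2 of the 2 values shown sit. Compound 3 `N#Cc1ccc(-c2ccc3[nH]c(=O)nc(-c4ccccc4)c3c2)cc1` differs from compound 2 by 4-cyanophenyl in place of 3-fluorophenyl on an aromatic carbon. Among the measured compounds shown here, the only measured step bears on this change but yields no size, so no direction can be expected beyond the scatter, and compound 3 is expected to stay near the limit. Compound 3 is therefore estimated at 70000 nM, with a range from 25000 nM to 250000 nM. The step that the limit leaves unreadable from compound 2 to compound 3 is thus expected to be small.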

Compound 3, half-maximal effective concentration: > 50000 nM
Compound 3: a limit, no number; the forecaster's own chance of this, stated with the estimate: 85%; the middle value does not contradict the limit.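

In this assay compound 3 gives > 50000 nM, a limit and not a number. No step among compound 1, compound 2 and compound 3 can be read, because all three share one value: the limit of > 50000 nM in this assay, at which 3 of the 3 values shown sit.

The compounds shown leave open whether 3-fluorophenyl or 4-cyanophenyl changes the concentration needed for the effect at all.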